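Methoxy to Hydroxy on a Diaryl Pyrazole Urea Series

A few compounds are considered here, and "the series" means these few. Any claim that something is new, unique, unknown or untested is made for them only; others in the source may bear on it.

Measured compounds:
compound 1, `O=C(Nc1cccc(-n2cc(-c3ccncc3)c(-c3ccc(Cl)c(O)c3)n2)c1)Nc1cccc(C(F)(F)F)c1`, 19100 nM
compound 2, `COc1cc(-c2nn(-c3cccc(NC(=O)Nc4ccc(Cl)c(Cl)c4)c3)cc2-c2ccncc2)ccc1Cl`, 3110 nM

Of the compounds shown here, two have been tested in a functional assay on UACC-257 cells (Homo sapiens) for inhibition, read by sulforhodamine B assay, with a stated time of 48 h; a higher number here means a weaker inhibitor of growth, a lower number a stronger inhibitor of growth. Compound 2 gives 3110 nM, the lowest of the two numbers. Its nearest neighbour, compound 1, gives 19100 nM, a gap that lies beyond the usual scatter. The two differ in more than one place, so the gap cannot be assigned to a single change.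

Compound 3, `O=C(Nc1cccc(-n2cc(-c3ccncc3)c(-c3ccc(Cl)c(O)c3)n2)c1)Nc1ccc(Cl)c(Cl)c1`, has not yet been measured. It is obtained from compound 2 by hydrogen in place of methyl on an oxygen on an aromatic ring. Compound 3 shares the hydroxy-bearing aryl ring with compound 1 and the dichlorophenyl urea with compound 2. Among the compounds with values here, no pair of measured compounds isolates the methoxy-to-hydroxy change, so its effect must be guessed. Since compound 1, which carries the hydroxy, gives 19100 nM, a modest weakening is expected, with a step of a 2.1-fold higher number from compound 2 to compound 3 (0.32 log units; beyond the scatter) in this assay. Compound 3 is therefore estimated at 6500 nM, within a range from 2000 nM to 21000 nM.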

Compound 3, concentration for total growth inhibition: 3160 nM
Compound 3: middle estimate off by 2.1-fold (0.31 log units), on the high side; the measured number falls inside the stated range.
By their numbers in this assay, from the lowest: compounds 2 and 3 (each within the scatter of the next); then compound 1.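

In this assay, replacing the methoxy of the 4-chloro-3-methoxyphenyl group with hydroxy gives a 1.0-fold higher number from compound 2 to compound 3 (0.01 log units; within the scatter), so with the 3,4-dichlorophenyl urea in place, the two groups cannot be told apart at this position on the aromatic ring. Within the data shown here, compound 3 also provides the first comparison that changes only the aryl group on the urea: with the 4-chloro-3-hydroxyphenyl group held constant, putting 3,4-dichlorophenyl in place of 3-(trifluoromethyl)phenyl gives a 6.0-fold lower number from compound 1 to compound 3 (0.78 log units; beyond the scatter), a step beyond the scatter, and this single change therefore moves the number where the methoxy-to-hydroxy change does not. The compounds shown come with no measurement that could explain either step.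

From the compounds shown here alone, whether methoxy and hydroxy would also match when the urea carries 3-(trifluoromethyl)phenyl remains open, so this result rests on a single pair with one urea group. Going by these compounds, it is equally open whether an amine, a carboxylic acid or a longer chain such as ethoxy on this ring would leave the number in the same place, or whether 3,4-dichlorophenyl would keep its edge over 3-(trifluoromethyl)phenyl with those groups present.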